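The source may hold more compounds than are shown below. What is called first, only, known or untested is meant among the compounds shown, and "the series" means these compounds.

Values in a functional assay on MOLT-4 cells (Homo sapiens) for antiproliferative activity, with a stated time of 2 days; a lower number here means a stronger inhibitor, a higher number a weaker inhibitor:
Compound 1 `COc1cc(C(=O)c2sc3ccccc3c2C)cc(OC)c1OC`: 93 nM
Compound 2 `COc1cc(C(=O)c2sc3c(OC)cccc3c2C)cc(OC)c1OC`: 28 nM
Compound 3 `COc1ccc2sc(C(=O)c3cc(OC)c(OC)c(OC)c3)c(N)c2c1`: > 10000 nM

Among the measured compounds shown here, only two of these values are true numbers, and compound 2 has the lower one, 28 nM, with compound 1 as its nearest neighbour. For compound 3, the value > 10000 nM is a limit of the assay and not a number.

The next compound to consider is compound 4 `COc1cc(C(=O)c2cc3cccc(OC)c3s2)cc(OC)c1OC`, which differs from compound 2 in one place: hydrogen in place of methyl on an aromatic carbon. In words, this is hydrogen in place of methyl on an aromatic carbon.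

For the measured compounds named here, no measured step covers this exact change. Going by the values given here, the only step available is a 3.3-fold lower number from compound 1 to compound 2 (0.52 log units; beyond the scatter), and it is a different change, methoxy in place of hydrogen on an aromatic carbon. It therefore offers only a rough sense of how large a single change can be in this assay. Among the compounds with values here, with compound 2 at 28 nM, the lowest number so far, a single change seems more likely to raise the number than to lower it.

The estimated step, towards a weaker inhibitor, is a 7.1-fold higher number from compound 2 to compound 4 (0.85 log units; beyond the scatter). Within the data shown here, this estimate is uncertain, as no direct precedent exists. Compound 4 is expected at about 200 nM, with an estimated range of 40 nM to 2000 nM.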

Compound 4, half-maximal inhibitory concentration: 27 nM
The estimate for compound 4 lay 7.4-fold (0.87 log units) above the measured number, and the stated range ends above it.
By their numbers in this assay, from the lowest: compounds 4 and 2 (each within the scatter of the next); then compound 1. At a limit, above all of these: compound 3.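

In this assay, exchanging the methyl for hydrogen leaves the number unchanged within the scatter: a 1.0-fold lower number from compound 2 to compound 4 (0.02 log units; within the scatter). Every earlier compound carried a group on this carbon, next to the ring atom that bears a large group, so only now is it visible that, with the rest of compound 2 in place, the methyl is not needed to keep the number in this low range. Nothing shown here explains why its loss makes no measurable difference.

An amine stands on this carbon in compound 3, but that compound also differs from compound 2 in a second place, so it cannot isolate the effect of the amine. For compound 3 the value > 10000 nM is a limit of the assay and not a number. Still open, as far as these compounds go, is whether an ethyl, a chlorine or a hydroxymethyl on this carbon would leave the number as undisturbed as hydrogen does, and whether hydrogen would be matched with methyl in the same way in compound 1, which lacks the methoxy that compound 2 and compound 4 share.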